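This account rests on a few compounds, and the source may have more. Where it says the series, first, only, none or still open, it means among the compounds named here.

- Compound 1 `CCCCOc1cccc(C[C@H]2C(=O)OC[C@@H]2Cc2ccccc2)c1` gives 26000 nM
- Compound 2 `Clc1ccc(C[C@H]2COC[C@@H]2Cc2ccccc2)cc1Cl` gives 19000 nM
- Compound 3 `COc1ccccc1C[C@H]1COC[C@@H]1Cc1ccc(Cl)c(Cl)c1` gives 55000 nM

In a functional assay on HL-60 cells (Homo sapiens) for cytotoxicity, read by WST assay, with a stated time of 48 h (on this read-out lower numbers stand for an effect already at smaller amounts and higher numbers for an effect only at larger amounts of compound), compound 2 (19000 nM) and compound 1 (26000 nM) lie within the usual scatter of each other, while compound 3 (55000 nM) carries a clearly higher number than compound 2.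

Compound 4 `Oc1cccc(C[C@H]2COC[C@@H]2Cc2ccc(Cl)c(Cl)c2)c1` departs from compound 2 by a single change hydroxy in place of hydrogen on an aromatic carbon and this can also be read as phenyl to 3-hydroxyphenyl. Among the measured compounds shown here, only one measured step resembles it. Methoxy in place of hydrogen on an aromatic carbon gave a 2.9-fold higher number from compound 2 to compound 3 (0.46 log units; beyond the scatter) and that modest step points towards a higher number. Compound 1 differs from compound 2 in more than one place and offers no clean comparison. For the measured compounds named here, no compound with a hydroxy group has been measured yet, so this guide is a rough one. A small rise, perhaps no larger than the scatter, therefore seems likely. The step expected in this assay is a 1.3-fold higher number from compound 2 to compound 4 (0.12 log units; within the scatter) as an estimate. For compound 4 the estimated value is 25000 nM with an expected range from 9000 nM to 60000 nM overall.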

Compound 4, half-maximal effective concentration: 31000 nM
The estimate for compound 4 lay 1.2-fold (0.09 log units) below the measured number; the measured number falls inside the stated range.
By their numbers in this assay, from the lowest: compounds 2, 1, 4 and 3 (each within the scatter of the next, the first and the last beyond it).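

In this assay hydroxy on an aromatic carbon, meta to a large group, gives a 1.6-fold higher number from compound 2 to compound 4 (0.21 log units; within the scatter) and so adds a hydrogen-bond donor and acceptor at this place on the ring without a difference that stands clear of the scatter. The earlier methoxy change gave a 2.9-fold higher number from compound 2 to compound 3 (0.46 log units; beyond the scatter) but that group stands at a different place on the ring, so the two steps differ in both group and place and do not show which of the two matters. Nothing available explains the result for the hydroxy group.

On these data alone, whether an amine or a carboxylic acid at this same place would also stay within the scatter of compound 2 remains open. So does the outcome of moving the hydroxy group to another carbon of this ring, or of placing a methoxy group exactly where the hydroxy group stands.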